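The source may report more compounds than this note shows. Statements on the series, on what has been measured and on what is new or still open speak of the compounds shown alone.

Compound 1 `C/C=C/C(=O)Nc1cc2c(N3CCc4ccccc43)ncnc2cc1OC` and compound 2 `CC/C=C/C(=O)Nc1cc2c(N3CCc4ccccc43)ncnc2cc1OC` share one core, and in a functional assay on PC-3 cells (Homo sapiens) for antiproliferative activity, read by MTT assay, with a stated time of 72 h (a lower number here means a stronger inhibitor, a higher number a weaker inhibitor), compound 1 gives 8120 nM while compound 2 gives 5890 nM. The change between them is methyl in place of hydrogen on a saturated chain carbon bound to a double-bonded chain carbon, and it made a 1.4-fold lower number from compound 1 to compound 2 (0.14 log units; within the scatter). Compound 3 `CC/C=C/C(=O)Nc1cc2c(N3CCCc4ccccc43)ncnc2cc1OC` carries a different core; how the two cores differ is not broken down here. In this assay compound 3 gives 6310 nM. Compound 4 `COc1cc2ncnc(N3CCCc4ccccc43)c2cc1NC(=O)/C=C/C(C)C` has not yet been measured and differs from compound 3 by methyl in place of hydrogen on a saturated chain carbon bound to a double-bonded chain carbon and a saturated chain carbon. Within the data shown here, this is the same kind of change as the one from compound 1 to compound 2, but its place is not identical: the saturated chain carbon is here bound to a double-bonded chain carbon and a saturated chain carbon, rather than to a double-bonded chain carbon alone. The expectation rests on the earlier step of a 1.4-fold lower number from compound 1 to compound 2 (0.14 log units; within the scatter). For compound 4 a step of similar size is expected, a 1.3-fold lower number from compound 3 to compound 4 (0.10 log units; within the scatter). Compound 4 is therefore estimated at 5000 nM in this assay, most likely between 2500 nM and 11000 nM.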

Compound 4, half-maximal inhibitory concentration: 8430 nM
The estimate for compound 4 lay 1.7-fold (0.23 log units) below the measured number; the range from low to high includes it.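

In this assay, the change from but-1-en-1-yl to 3-methylbut-1-en-1-yl gave a 1.3-fold higher number from compound 3 to compound 4 (0.13 log units; within the scatter). Set beside the earlier methyl step on the other core, the two steps cannot be told apart: the same change on two cores in this assay, a 1.4-fold lower number (0.14 log units; within the scatter) from compound 1 to compound 2 and a 1.3-fold higher number (0.13 log units; within the scatter) from compound 3 to compound 4, 1.8-fold (0.27 log units) apart, within the scatter of two such steps. This shows that neither step stands out from the scatter on its core, so nothing here points to a dependence on the core; it does not show that the step carries over unchanged, for each step rests on a single pair and the methyl's place is not identical in the two.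

The compounds shown leave open whether a longer chain or an amine in place of this methyl would move the number beyond the scatter on either core.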